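The compounds below may be only part of what the source reports. "The series", "measured", "known", "first", "only" and "open" are said of these compounds alone.

Working notes on the step from compound 2 (`Nc1nc(NCCNc2ncc(-c3ncc[nH]3)c(-c3ccc(Cl)cc3)n2)ccc1[N+](=O)[O-]`) to compound 4 (`Nc1nc(NCCNc2ncc(-c3ncc[nH]3)c(-c3ccc(F)cc3Cl)n2)ccc1[N+](=O)[O-]`). In an ADME assay on microsomes from liver (Rattus norvegicus) for metabolic stability (a higher number here means that the compound lasts longer, a lower number that the compound disappears faster), compound 2 gives > 0.5 h as a limit of the assay, not a number. Compound 1 (`Clc1ccc(-c2nc(NCCNc3ccccn3)ncc2-c2ncc[nH]2)c(Cl)c1`) gives > 0.5 h and that too is a limit. Compound 3 (`Nc1nc(NCCNc2ncc(-c3ncc[nH]3)c(-c3ccc(F)cc3F)n2)ccc1[N+](=O)[O-]`) gives > 0.5 h and that is also a limit. For the measured compounds named here, the series so far therefore reads as the limit of > 0.5 h in this assay, at which 3 of the 3 values shown sit, and no measured compound has a readable half-life.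

The structural change is 2-chloro-4-fluorophenyl in place of 4-chlorophenyl on an aromatic carbon and it sits on an aromatic carbon next to the ring nitrogen of the shared core. Going by the values given here, the one measured step that bears on it alters the same phenyl group, with 2,4-difluorophenyl in place of 4-chlorophenyl. That change gives a step that the two limits leave unreadable from compound 2 to compound 3 and so offers no size to carry over.

With no readable size available, no step beyond the scatter is expected in this assay and no direction is assigned. The estimated change is a step that the limit leaves unreadable from compound 2 to compound 4 and it should be read against a limit rather than a number. A report of compound 4 as a limit is the likelier outcome. For compound 4 the estimated half-life is 0.8 h with an expected range from 0.45 h to 1.6 h in this assay.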

Compound 4, half-life: > 0.5 h
Compound 4 was reported as a limit; the forecaster's own chance of this, stated with the estimate: 85%; the middle value does not contradict the limit.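

In this assay compound 4 gives > 0.5 h, which is a limit and not a number. The comparisons of compound 4 with compound 2 and compound 3 therefore yield no readable step, and the series stays where it was: the limit of > 0.5 h in this assay, at which 4 of the 4 values shown sit.

The compounds shown leave open the actual half-life of each compound and whether any change on the phenyl group alters it.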